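A few compounds are considered here, and "the series" means these few. Any claim that something is new, unique, unknown or untested is made for them only; others in the source may bear on it.

Measured in a functional assay on CCRF-CEM cells (Homo sapiens) for inhibition; on this read-out lower numbers stand for stronger inhibition and higher numbers for weaker inhibition:

- Compound 1 `Cc1cccc(/C=C2\Cc3ccccc3C2=O)c1`: 41300 nM
- Compound 2 `O=C1CCCCC/C1=C\c1cccc(Cl)c1`: 40500 nM

On these two numbers, compound 2 stands level with compound 1, and the gap between them lies within the scatter. Among the measured compounds shown here, the two compounds differ in more than one place, so no measured step shows what a single change does here.

The next compound, compound 3 `COc1cccc(/C=C2\CCCCCC2=O)c1`, is compound 2 with methoxy in place of chloro on an aromatic carbon. For the measured compounds named here, with no measured step to draw on, the expectation in this assay rests on compound 2 at 40500 nM, and no shift beyond the scatter is expected in either direction. The expected step is a 1.0-fold lower number from compound 2 to compound 3 (0.01 log units; within the scatter). For compound 3 the estimated value is 40000 nM, with an expected range from 15000 nM to 100000 nM.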

Compound 3, half-maximal inhibitory concentration: 128000 nM
Estimate against measurement, compound 3: 3.2-fold (0.51 log units) below; the measured number lies above the stated range.
By their numbers in this assay, from the lowest: compounds 2 and 1 (each within the scatter of the next); then compound 3.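

In this assay, the aromatic position that carries chloro in compound 2 is not indifferent to its substituent: methoxy in place of chloro gives a 3.2-fold higher number from compound 2 to compound 3 (0.50 log units; beyond the scatter), a modest change towards weaker inhibition but one beyond the scatter. Among the compounds shown here, compounds 1 and 2 differ in more than one place, so this is the first single change that can be read. No evidence is available that explains the step.

Whether the weaker inhibition is particular to methoxy remains open, as the compounds shown do not reveal how an amine or a carboxylic acid would behave on this aromatic carbon. It is equally unresolved whether the same exchange would produce a comparable step on the core of compound 1.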